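The source may hold more compounds than are shown below. What is called first, only, known or untested is meant among the compounds shown, and "the series" means these compounds.

Measured in a functional assay (muscle tissue) with Cavia porcellus as the target; a higher number here means that more compound is needed for the effect, a lower number that less compound is needed:
- compound 1 `COC(=O)C1=C(C)N=C(C)/C(=C(\O)OC)C1c1ccc(Br)cc1`: 540 nM
- compound 2 `COC(=O)C1=C(C)N=C(C)/C(=C(\O)OC)C1c1cccc(C#N)c1`: 34.7 nM
- compound 3 `COC(=O)C1=C(C)N=C(C)/C(=C(\O)OC)C1c1ccc(C#N)cc1`: 3470 nM

Compound 3 has the highest number of the three, so it needs the most compound for the effect. Compound 4 `COC(=O)C1=C(C)N=C(C)/C(=C(\O)OC)C1c1cccc(F)c1` has not yet been measured. It carries 3-fluorophenyl in place of 4-cyanophenyl on a saturated ring carbon.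

The most telling measurement is a 100-fold higher number from compound 2 to compound 3 (2.00 log units; beyond the scatter). Among the measured compounds shown here, there, the only change is from 3-cyanophenyl to 4-cyanophenyl, and this large step shows how much the placement of the group matters in this small set. Compound 4 resembles compound 2 in having its group at the 3 position of the phenyl ring. A second measurement, a 6.4-fold higher number from compound 1 to compound 3 (0.81 log units; beyond the scatter), shows that exchanging the group at one place can also shift the number, though only modestly here. For the measured compounds named here, no measured compound carries fluoro, so the effect of replacing cyano with fluoro remains unknown. A large move to a lower number is therefore expected in this assay, probably slightly smaller than the full gap seen with compound 2, and it is estimated as a 50-fold lower number from compound 3 to compound 4 (1.70 log units; beyond the scatter). The expected value for compound 4 is 70 nM, with an estimated range from 15 nM to 350 nM.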

Compound 4, half-maximal effective concentration: 20.9 nM
Compound 4: the middle estimate sits 3.3-fold (0.52 log units) above what was measured; the range from low to high includes it.
By their numbers in this assay, from the lowest: compounds 4 and 2 (each within the scatter of the next); then compound 1; then compound 3.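

In this assay, the two compounds with a group at the 3 position of the phenyl ring cannot be told apart (a 1.7-fold lower number from compound 2 to compound 4 (0.22 log units; within the scatter)), so the low number of compound 2 is not unique to its nitrile: fluoro, a much smaller group by atom count, gives a result within the scatter of it at this place. The two large steps to 3-fluorophenyl (a 170-fold lower number from compound 3 to compound 4 (2.22 log units; beyond the scatter) and a 26-fold lower number from compound 1 to compound 4 (1.41 log units; beyond the scatter)) extend the pattern seen so far, with no exception among these four compounds: both 3-substituted phenyl compounds have lower numbers than both 4-substituted ones, though each of these two steps changes the group and its place together. Nothing available explains why the place on the phenyl ring matters so much here.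

Bromo appears only in 4-bromophenyl and fluoro only in 3-fluorophenyl, so for these two groups the effect of the place cannot be separated from the effect of the group. On these data alone, it also remains open how a quite different group at the 3 position, such as an amine or a carboxylic acid, would behave.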